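This account rests on a few compounds, and the source may have more. Where it says the series, first, only, none or still open, it means among the compounds named here.

Working notes on the series. Compound 1 `Nc1cc(N)c2nc(-c3ccccc3)c(Oc3ccc(Cl)c(Cl)c3)nc2c1` carries the 3,4-dichlorophenoxy group on the shared core. In a functional assay on OVCAR-8 cells (Homo sapiens) for inhibition, read by sulforhodamine B assay, with a stated time of 48 h (on this read-out higher numbers stand for lower toxicity in this test and lower numbers for higher toxicity in this test), compound 1 gives only a limit, < 100000 nM. Compound 2 `Nc1cc(N)c2nc(-c3ccccc3)c(Sc3ccc(Cl)c(Cl)c3)nc2c1` carries the (3,4-dichlorophenyl)sulfanyl group in its place. In this assay compound 2 likewise gives only a limit, < 100000 nM. The step that the two limits leave unreadable from compound 1 to compound 2 is therefore not readable, since both values sit at the limit of < 100000 nM in this assay, at which 2 of the 2 values shown sit. Compound 3 `Nc1cc(N)c2nc(-c3ccccc3)c(Oc3ccc(F)cc3)nc2c1` differs from compound 2 by 4-fluorophenoxy in place of (3,4-dichlorophenyl)sulfanyl on an aromatic carbon. Among the compounds with values here, no measured step bears on this change, and the two limits fix no size for any step. The expected step that the limit leaves unreadable from compound 2 to compound 3 is thus of unreadable size, with a limit again likely. Compound 3 is estimated at 30000 nM, within 5000 nM to 100000 nM.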

Compound 3, concentration lethal to 50% of the cells: 100000 nM
Beside the measured number, compound 3's estimate is 3.3-fold (0.52 log units) below it; the range from low to high includes it.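

In this assay, within the data shown here, compound 3 gives 100000 nM, the first number at this position rather than a limit, with a number no lower from compound 2 to compound 3 (the limit leaves the size open) and a number no lower from compound 1 to compound 3 (the limit leaves the size open). It shows that a 4-fluorophenoxy group on this aromatic carbon can give a readable value, but neither step can be read in size. Most of the values shown remain limits: the limit of < 100000 nM in this assay, at which 2 of the 3 values shown sit.

Still open, on these data alone, is how the 4-fluorophenyl group reads on sulfur in place of oxygen. Also open, as far as these compounds go, is how an amine or a carboxylic acid at this position would read in this test.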